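A few compounds are considered here, and "the series" means these few. Any claim that something is new, unique, unknown or untested is made for them only; others in the source may bear on it.

Three thiosemicarbazone-type compounds built on a pyridine amidrazone were tested in a functional assay on A-431 cells (Homo sapiens) for cytotoxicity, read by MTT assay, with a stated time of 72 h, tested at 30 uM; a higher number here means more inhibition of growth at the concentration tested, a lower number less inhibition of growth. Compound 1 `Cc1cccc(/C(N)=N/NC(=S)N2CCSCC2)n1` gives 64.5%. Compound 3 `N/C(=N\NC(=S)N1CCSCC1)c1ccccn1` carries a thiomorpholine like compound 1. In this assay compound 3 gives 81.3%. The step of a number 16.8 percentage points higher from compound 1 to compound 3 (beyond the scatter) comes from a single change, (hydrogen in place of methyl on an aromatic carbon). Compound 2 `Cc1ccnc(/C(N)=N/NC(=S)N2CCN(c3ccccn3)CC2)c1`, which carries a pyridinyl-piperazine in place of the thiomorpholine, gives 65.7%; the difference between the core of compound 2 and the core of compound 1 is not broken down here. The values of compound 1 and compound 2 sit within the scatter of each other, so no order between them can be stated.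

Compound 4 `N/C(=N\NC(=S)N1CCN(c2ccccn2)CC1)c1ccccn1` is the pyridinyl-piperazine counterpart of compound 3 and has not yet been measured. It differs from compound 2 by hydrogen in place of methyl on an aromatic carbon. This is the same kind of change as from compound 1 to compound 3, but not the same: in compound 1 the methyl that leaves sits next to the ring nitrogen, whereas in compound 2 it sits opposite the ring nitrogen, both being meta to a large group.

Because the step of a number 16.8 percentage points higher from compound 1 to compound 3 (beyond the scatter) was a gain in this assay, a step of similar direction is expected for compound 4, estimated as a number 11.3 percentage points higher from compound 2 to compound 4 (beyond the scatter), with some doubt since the place of the methyl differs. Compound 4 is thus expected to give about 77%, likely between 62% and 90%.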

Compound 4, percent growth inhibition at one concentration: 74.9%
Estimate against measurement, compound 4: 2.1 percentage points above; the range from low to high includes it.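

In this assay, the exchange of methyl for hydrogen, read here as 4-methylpyridin-2-yl to pyridin-2-yl, gives a number 9.2 percentage points higher from compound 2 to compound 4 (within the scatter), so this step taken alone cannot be told apart from the scatter of repeated measurements. Set beside the earlier step, it points the same way, and the size of the change does not measurably differ between the two cores: the same change on two cores in this assay, a number 16.8 percentage points higher (beyond the scatter) from compound 1 to compound 3 and a number 9.2 percentage points higher (within the scatter) from compound 2 to compound 4, 7.6 percentage points apart, within the scatter of two such steps

This fits a change that carries from one core to the other, but it does not establish that it does, since only two pairs are shown, just one of the two steps lies beyond the scatter, and the cores differ both in the place of the methyl and in the thiomorpholine or pyridinyl-piperazine they carry.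

The compounds shown leave open how the ring would respond to an ethyl group, a methoxy group, a chlorine atom or an amine at the place of the methyl. They also leave open whether a morpholine or a piperidine in place of the thiomorpholine or the pyridinyl-piperazine would shift the reading of growth inhibition, and whether the exchange of methyl for hydrogen would hold there too.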